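Thiourea to urea swap on a cytotoxicity read-out

The source may hold more compounds than are shown below. What is called first, only, known or untested is meant among the compounds shown, and "the series" means these compounds.

Of the compounds shown here, two of a shared core have been tested in an ADME assay on PBL cells (Homo sapiens) for cytotoxicity, read by MTT assay, with a stated time of 72 h; a higher number here means a weaker inhibitor, a lower number a stronger inhibitor. Compound 1 `COc1cc2c(Oc3ccc(NC(=O)N/N=C/c4cccs4)cc3F)ccnc2cc1OCCCN1CCCCC1` gives 68700 nM in this assay, and compound 2 `COc1cc2c(Oc3ccc(NC(=S)N/N=C/c4ccccc4)cc3F)ccnc2cc1OCCCN1CCCCC1` gives 78400 nM. On the two numbers available, compound 2 carries the higher figure, but the step of a 1.1-fold higher number from compound 1 to compound 2 (0.06 log units; within the scatter) lies within the scatter, so no order between the two can be claimed.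

Compound 3 `COc1cc2c(Oc3ccc(/C=N/NC(=O)Nc4ccccc4)cc3F)ccnc2cc1OCCCN1CCCCC1` differs from compound 2 by a group of 12 heavy atoms (8 carbon, 3 nitrogen, 1 oxygen; one six-membered aromatic ring of carbon only) in place of a group of 12 heavy atoms (8 carbon, 3 nitrogen, 1 sulfur; one six-membered aromatic ring of carbon only), on an aromatic carbon. Within the data shown here, the only measured step, a 1.1-fold higher number from compound 1 to compound 2 (0.06 log units; within the scatter), also swaps a carbonyl-bearing urea chain for a thiocarbonyl-bearing one alongside a change of ring, and it moved the number hardly at all. The change from compound 2 to compound 3 runs the other way, thione to carbonyl, with the chain attached in reversed sense, and nothing in the data points to a shift beyond the scatter in this assay in either direction.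

Compound 3 is therefore expected to give about 70000 nM in this assay, estimated between 30000 nM and 160000 nM, a step of a 1.1-fold lower number from compound 2 to compound 3 (0.05 log units; within the scatter) that is expected to stay within the scatter.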

Compound 3, half-maximal inhibitory concentration: 25500 nM
Beside the measured number, compound 3's estimate is 2.7-fold (0.44 log units) above it, and the stated range ends above it.
By their numbers in this assay, from the lowest: compound 3; then compounds 1 and 2 (each within the scatter of the next).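

In this assay, among these compounds, the aromatic carbon para to a large group proves to be a place where a change can register: a 3.1-fold lower number from compound 2 to compound 3 (0.49 log units; beyond the scatter), the first step in the set to pass beyond the scatter, and it comes with an entering group that matches the leaving one in its heavy-atom count, its ring and its hydrogen-bond donors and acceptors, with oxygen in place of sulfur. The other new step, a 2.7-fold lower number from compound 1 to compound 3 (0.43 log units; beyond the scatter), is likewise beyond the scatter, so compound 3 holds the lowest number of the three, though both steps are modest and the earlier step between compound 1 and compound 2 stayed within the scatter. Nothing available gives a reason for this shift in the number.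

The compounds shown do not separate the exchange of sulfur for oxygen from the reversed attachment of the chain, so which of the two carries the step remains open. As far as these compounds go, how a chain ending in an amine or a carboxylic acid on this same aromatic carbon would read in this assay also remains open.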